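Swapping the amine ring on the propoxy chain

The source may report more compounds than this note shows. Statements on the series, on what has been measured and on what is new or still open speak of the compounds shown alone.

- Compound 2 `COc1cc2c(Oc3ccc(NC(=O)c4nn(-c5cccc(F)c5)c(=O)cc4C)cc3F)ccnc2cc1OCCCN1CCCC1`: 120 nM
- Compound 1 `COc1cc2c(Oc3ccc(NC(=O)c4nn(-c5ccccc5C(F)(F)F)c(=O)cc4C)cc3F)ccnc2cc1OCCCN1CCC(C)CC1`: 60 nM

In a functional assay on MKN-45 cells (Homo sapiens) for inhibition, read by MTT assay, with a stated time of 72 h (a lower number here means a stronger inhibitor, a higher number a weaker inhibitor), compound 2 gives 120 nM. Compound 2 has the higher of the two numbers, with compound 1 at 60 nM, a gap that lies within the scatter, so the two cannot be ordered.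

Compound 3 `COc1cc2c(Oc3ccc(NC(=O)c4nn(-c5cccc(F)c5)c(=O)cc4C)cc3F)ccnc2cc1OCCCN1CCC(C)CC1` has not yet been measured. It differs from compound 2 in one place: 4-methylpiperidin-1-yl in place of pyrrolidin-1-yl on a saturated chain carbon, three bonds along the chain from an oxygen on an aromatic ring. Going by the values given here, no measured pair isolates this change, and compound 1 differs from compound 3 in another part of the molecule, so it offers only a rough anchor.

The step from compound 2 to compound 3 is expected to be small, a 1.4-fold lower number from compound 2 to compound 3 (0.15 log units; within the scatter), and not beyond the scatter. The estimate for compound 3 in this assay is 85 nM, in the range 30 nM to 250 nM.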

Compound 3, half-maximal inhibitory concentration: 140 nM
The estimate for compound 3 lay 1.6-fold (0.22 log units) below the measured number; the range from low to high includes it.
By their numbers in this assay, from the lowest: compounds 1, 2 and 3 (each within the scatter of the next, the first and the last beyond it).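

Replacing pyrrolidin-1-yl with 4-methylpiperidin-1-yl on the propyl chain gives a 1.2-fold higher number from compound 2 to compound 3 (0.07 log units; within the scatter) in this assay, so compound 2 and compound 3 cannot be ordered, and this position tolerates the change of ring within this pair. The other single change, 3-fluorophenyl in place of 2-(trifluoromethyl)phenyl on an aromatic nitrogen, gives a 2.3-fold higher number from compound 1 to compound 3 (0.37 log units; beyond the scatter), a modest step and the only one of the two that clears the scatter. Nothing available explains either result.

Going by these compounds, it remains open whether a ring carrying a second hetero atom, such as morpholin-4-yl, or an open-chain amine, such as dimethylamino, would fit this position equally well. It is also unclear whether pyrrolidin-1-yl and 4-methylpiperidin-1-yl would stay level alongside the 2-(trifluoromethyl)phenyl group.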